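A few compounds are considered here, and "the series" means these few. Any claim that something is new, unique, unknown or untested is made for them only; others in the source may bear on it.

Measured in an ADME assay on MDBK cells (Bos taurus) for cytotoxicity, read by MTT assay, with a stated time of 96 h; a lower number here means that less compound is tolerated, a higher number that more compound is tolerated:
- Compound 1 `CC(=O)c1ccc2c(c1)nc(-c1ccc(C(F)(F)F)cc1)n2C1CCCCC1`: 52000 nM
- Compound 2 `C/C(=N\NC(N)=O)c1ccc2c(c1)nc(-c1ccccc1)n2C1CCCCC1`: > 100000 nM (a limit, not a number)
- Compound 3 `C/C(=N\NC(N)=O)c1ccc2c(c1)nc(-c1ccc(Cl)cc1)n2C1CCCCC1`: > 100000 nM (a limit, not a number)

Compound 3 has no numerical value in this assay. Its result of > 100000 nM is only a limit. Compound 2 gives > 100000 nM, which is also a limit, so the series is dominated by the limit of > 100000 nM in this assay, at which 2 of the 3 values shown sit.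

Compound 4 `C/C(=N\NC(N)=O)c1ccc2c(c1)nc(-c1ccc(C(F)(F)F)cc1)n2C1CCCCC1` has not yet been measured. It differs from compound 3 as follows: trifluoromethyl in place of chloro on an aromatic carbon. In words, trifluoromethyl replaces chloro on an aromatic carbon, turning 4-chlorophenyl into 4-(trifluoromethyl)phenyl.

For the measured compounds named here, the one measured step on this aromatic carbon is a step that the two limits leave unreadable from compound 2 to compound 3, and it offers no size to carry forward. Going by the values given here, the only numerical value comes from compound 1, at 52000 nM. Compound 1 carries the same 4-(trifluoromethyl)phenyl group as compound 4 but differs from it elsewhere. That value gives some reason to allow for a result just under the limit, so any expected shift would be towards less compound being tolerated, and it may not exceed the scatter.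

The expected change is an at least 1.0-fold lower number from compound 3 to compound 4 (0.02 log units; that floor lies within the scatter). For compound 4 the estimated value is 95000 nM, with an expected range of 45000 nM to 150000 nM.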

Compound 4, half-maximal cytotoxic concentration: > 100000 nM
Compound 4: no number, only a limit; the forecaster's own chance of this, stated with the estimate: 65%; at least 1.0-fold (0.02 log units) between middle value and limit.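

In this assay compound 4 gives > 100000 nM, which is a limit and not a number. For the compounds shown here, the steps from compound 2 and compound 3 to compound 4 cannot be read, but trifluoromethyl on this aromatic carbon now joins hydrogen and chloro at the same ceiling, so the series remains held there: the limit of > 100000 nM in this assay, at which 3 of the 4 values shown sit. With the 4-(trifluoromethyl)phenyl group shared, compound 1 and compound 4 differ only in the other group on an aromatic carbon, and this pair gives the first step with any readable size, an at least 1.9-fold higher number from compound 1 to compound 4 (0.28 log units; that floor lies within the scatter).

On these data alone, it remains open how far compound 2, compound 3 and compound 4 lie past the limit, and so whether hydrogen, chloro and trifluoromethyl differ at all in this measurement. The compounds shown also leave open how an amine or a carboxylic acid in place of trifluoromethyl on this aromatic carbon would read, and whether any such group would bring a compound with the longer side group under the limit.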